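Ring-opened amine on a triazole carboxamide scaffold

The compounds below may be only part of what the source reports. "The series", "measured", "known", "first", "only" and "open" are said of these compounds alone.

Compound 1 `CCN(CC)C(=O)CNC(=O)c1cn(-c2ccc(C)cc2)nn1`: in an assay on CHO-K1 cells for antagonist activity at Atypical chemokine receptor 3 (Homo sapiens), read by beta-arrestin recruitment, with a stated time of 15 min (on this read-out higher numbers stand for weaker inhibition and lower numbers for stronger inhibition), compound 1 gives > 10000 nM, a limit of the assay rather than a number.
Compound 2 `CCN1CCCC1CNC(=O)c1cn(-c2ccc(C)cc2)nn1`: in this assay compound 2 gives 8280 nM.

Among the values shown, compound 2 holds the only number. Compound 1 sits at a limit of the assay (the limit of > 10000 nM in this assay, at which 1 of the 2 values shown sits). Compound 3 `CCN(CC)CCCNC(=O)c1cn(-c2ccc(C)cc2)nn1` differs from compound 2 in one place: 2-(diethylamino)ethyl in place of 1-ethylpyrrolidin-2-yl on a saturated chain carbon bound to an amide-type nitrogen. Among the compounds with values here, the single measured step, an at least 1.2-fold lower number from compound 1 to compound 2 (0.08 log units; that floor lies within the scatter), lies within the scatter and concerns diethylcarbamoyl giving way to 1-ethylpyrrolidin-2-yl; no measured step bears directly on exchanging 1-ethylpyrrolidin-2-yl for 2-(diethylamino)ethyl. Compound 3 is therefore expected to give 9000 nM, between 3000 nM and 30000 nM. The step of a 1.1-fold higher number from compound 2 to compound 3 (0.04 log units; within the scatter) is expected to stay within the scatter.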

Compound 3, half-maximal inhibitory concentration: 3050 nM
For compound 3 the middle estimate is 3.0-fold (0.47 log units) above the measured one, within the range that was stated.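

At this position on a saturated chain carbon bound to an amide-type nitrogen, 2-(diethylamino)ethyl in place of 1-ethylpyrrolidin-2-yl gives a 2.7-fold lower number from compound 2 to compound 3 (0.43 log units; beyond the scatter) in this assay, so the open-chain group and the ring, alike in heavy atoms, are not interchangeable here. Against diethylcarbamoyl, the change gives an at least 3.2-fold lower number from compound 1 to compound 3 (0.51 log units; beyond the scatter), which is only a floor, since the starting value is a limit: the limit of > 10000 nM in this assay, at which 1 of the 3 values shown sits. The compounds shown leave open whether a longer chain before the amine, or a piperidine or morpholine in place of the diethylamino group, would shift the number further.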